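Fluorination of the sulfonyl side chain and stability

The source may report more compounds than this note shows. Statements on the series, on what has been measured and on what is new or still open speak of the compounds shown alone.

Measured in an ADME assay on S9 fraction from liver (Cricetinae) for metabolic stability; a higher number here means that the compound lasts longer, a lower number that the compound disappears faster:
Compound 1 `Cn1c(S(=O)(=O)Cc2ccccc2)nc(-c2ccccc2)c1-c1ccccc1` gives < 0.0417 h, a limit of the assay.
Compound 2 `Cn1c(S(=O)(=O)Cc2ccc(F)cc2)nc(-c2ccc(F)cc2)c1-c1ccc(F)cc1` gives < 0.0417 h, a limit of the assay.
Compound 3 `Cn1c(S(=O)(=O)C(F)c2ccc(F)cc2)nc(-c2ccccc2)c1-c1ccccc1` gives < 0.0417 h, a limit of the assay.

Compound 2 stands at the limit in this assay, and the two other values shown are limits as well (the limit of < 0.0417 h in this assay, at which 3 of the 3 values shown sit), so no order among the three can be read. Compound 4 `Cn1c(S(=O)(=O)C(F)(F)c2ccc(F)cc2)nc(-c2ccc(F)cc2)c1-c1ccc(F)cc1` differs from compound 2 by difluoro(4-fluorophenyl)methyl in place of 4-fluorobenzyl on a sulfonyl sulfur. Among the measured compounds shown here, the one measured step in the same direction, a step that the two limits leave unreadable from compound 1 to compound 3, is unreadable because the limit of < 0.0417 h in this assay, at which 3 of the 3 values shown sit, covers both of its ends. For the measured compounds named here, no measured step therefore shows whether the added fluorine lengthens the half-life. Compound 4 is expected to remain at the limit, with an estimate of 0.02 h, between 0.005 h and 0.08 h. The expected step that the limit leaves unreadable from compound 2 to compound 4 is none beyond the scatter, and the assay will most likely again report only a limit.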

Compound 4, half-life: 0.9 h
Compound 4: middle estimate off by 45-fold (1.65 log units), on the low side, and the stated range ends below it.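

In this assay, difluoro(4-fluorophenyl)methyl in place of 4-fluorobenzyl on a sulfonyl sulfur gives an at least 21-fold higher number from compound 2 to compound 4 (1.33 log units; beyond the scatter). Among the compounds shown here, this is the first readable step at this position, and it shows that a change in this side chain alone, with the rest of compound 2 kept, can lift the half-life off the limit. From the compounds shown here alone, the full size of the step stays unknown because its lower end is a limit: the limit of < 0.0417 h in this assay, at which 3 of the 4 values shown sit.

Going by these compounds, whether a different group on the sulfonyl sulfur, such as trifluoromethyl or a longer alkyl chain, would give a similar half-life remains open. Also open, on these data alone, is whether the same replacement carries over to the core of compound 1.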